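The source may hold more compounds than are shown below. What is called first, only, known or untested is meant among the compounds shown, and "the series" means these compounds.

Measured so far in an ADME assay on HEK-293T cells (Homo sapiens) for inhibition, read by CCK-8 assay, with a stated time of 48 h (a higher number here means a weaker inhibitor, a lower number a stronger inhibitor), both values being limits:
- compound 1 `COc1ccc(S(=O)(=O)Oc2ccccc2/C=C(\C#N)C(=O)Nc2nnc(-c3cccs3)s2)cc1` gives > 20000 nM
- compound 2 `COc1ccc(S(=O)(=O)Oc2ccccc2/C=C(\C#N)C(=O)Nc2nnc(Cc3ccc(F)cc3)s2)cc1` gives > 50000 nM

The entry for compound 2, > 50000 nM, is a limit and not a number, so its position in the series is known only as a limit.

Compound 3 `COc1ccc(S(=O)(=O)Oc2ccccc2/C=C(\C#N)C(=O)Nc2nnc(Cc3cccc(F)c3)s2)cc1` has the same atoms as compound 2, joined differently: 3-fluorophenyl in place of 4-fluorophenyl on a saturated chain carbon bound to an aromatic carbon. This is the move from 4-fluorobenzyl to 3-fluorobenzyl.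

For the measured compounds named here, the only measured step, a step that the two limits leave unreadable from compound 1 to compound 2, places 4-fluorobenzyl where thiophen-2-yl stood and offers no size to carry over. With no readable step to draw on, no change beyond the scatter is expected in this assay, and another limit is the likeliest report. The expected change is a number no higher from compound 2 to compound 3 (the limit leaves the size open).

For compound 3 the estimate is 50000 nM, with an expected range from 20000 nM to 100000 nM.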

Compound 3, half-maximal inhibitory concentration: > 50000 nM
Compound 3: no number, only a limit; the forecaster's own chance of this, stated with the estimate: 75%; the middle value sits exactly at the limit.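

In this assay compound 3 gives > 50000 nM, a limit and not a number. For the compounds shown here, no step among compound 1, compound 2 and compound 3 can be read. The compounds shown leave open how strongly each inhibits and whether 3-fluorobenzyl and 4-fluorobenzyl differ at all.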